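From 2-fluorophenyl to 3-fluorophenyl in compound 3

A few compounds are considered here, and "the series" means these few. Any claim that something is new, unique, unknown or untested is made for them only; others in the source may bear on it.

Compound 1 `COc1ccc([C@H]2CC(=O)N(c3cccc(S(C)(=O)=O)c3)C2)cc1OC1CCCC1`: > 10000 nM (a limit)
Compound 2 `COc1ccc([C@H]2CC(=O)N(c3cccc(NS(=O)(=O)c4ccccc4F)c3)C2)cc1OC1CCCC1`: > 10000 nM (a limit)

In a functional assay on HEK293 cells (Homo sapiens) for cytotoxicity (a higher number here means that more compound is tolerated, a lower number that less compound is tolerated), compound 2 gives > 10000 nM, which is a limit of the assay and not a number. Compound 3 `COc1ccc([C@H]2CC(=O)N(c3cccc(NS(=O)(=O)c4cccc(F)c4)c3)C2)cc1OC1CCCC1` has the same atoms as compound 2, joined differently: it carries 3-fluorophenyl in place of 2-fluorophenyl on a sulfonyl sulfur. Among the measured compounds shown here, the one measured step that bears on this change is a step that the two limits leave unreadable from compound 1 to compound 2, and it has no readable size. What the data offer is the limit of > 10000 nM in this assay, at which 2 of the 2 values shown sit. For the measured compounds named here, no measured step therefore points in either direction, and no change beyond the usual scatter is expected. The expected outcome is a step that the limit leaves unreadable from compound 2 to compound 3, and another limit is the most likely report. The estimate for compound 3 is 12000 nM, with an expected range of 7000 nM to 30000 nM.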

Compound 3, half-maximal cytotoxic concentration: > 10000 nM
Compound 3: a limit, no number; the forecaster's own chance of this, stated with the estimate: 90%; the middle value lies beyond the limit too.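

In this assay, among the compounds shown here, compound 3 gives > 10000 nM, a limit and not a number, so no step among compound 1, compound 2 and compound 3 can be read. The compounds shown leave open how much of each is tolerated, and whether 3-fluorophenyl and 2-fluorophenyl differ at all.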